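The source may hold more compounds than are shown below. What is called first, only, known or untested is meant among the compounds shown, and "the series" means these compounds.

Of the compounds shown here, two that share one core have been measured in an assay on HEK293 cells for agonist activity at Toll-like receptor 8 (Homo sapiens), read by a luciferase reporter, with a stated time of 6 h; a lower number here means that less compound is needed, a higher number that more compound is needed for the effect. Compound 1, `CCCCNc1nc(N)nc2c1CN(C(=O)c1ccncc1)CC2`, gives in this assay only a limit, > 25 uM, and not a number. Within the data shown here, compound 2, `CCCCNc1nc(N)nc2c1CN(C(=O)c1cnccn1)CC2`, gives 2.2 uM in this assay, and this is the only actual number among the two values shown. Among the measured compounds shown here, the single measured step, an at least 11-fold lower number from compound 1 to compound 2 (1.05 log units; beyond the scatter), is read against that limit, (the limit of > 25 uM in this assay, at which 1 of the 2 values shown sits).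

Compound 3, `CCCCNc1nc(N)nc2c1CN(C(=O)c1cnc(C)cn1)CC2`, differs from compound 2 in one place: methyl in place of hydrogen on an aromatic carbon. The measured step swaps the whole ring on the carbonyl carbon, pyrazin-2-yl in place of pyridin-4-yl, and says nothing about putting a methyl onto the pyrazin-2-yl ring, which compound 3 keeps. For the measured compounds named here, no measured step therefore bears directly on this change, and a step in this assay no larger than the usual scatter is expected, in either direction. Compound 3 is thus expected to give about 1.8 uM in this assay, between 0.6 uM and 6 uM. The step of a 1.2-fold lower number from compound 2 to compound 3 (0.09 log units; within the scatter) is expected to stay within the scatter.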

Compound 3, minimum effective concentration: 6.8 uM
Estimate against measurement, compound 3: 3.8-fold (0.58 log units) below; the whole stated range lies below it.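

The pyrazin-2-yl ring on the carbonyl is not indifferent to substitution: in this assay, a single methyl on an aromatic carbon, next to the ring nitrogen and para to a large group, brings a 3.1-fold higher number from compound 2 to compound 3 (0.49 log units; beyond the scatter), so more compound is needed for the same effect once this hydrogen is replaced. The cost does not remove the gain seen on leaving the pyridin-4-yl ring, since the 5-methylpyrazin-2-yl ring still gives an at least 3.6-fold lower number from compound 1 to compound 3 (0.56 log units; beyond the scatter). That second step rests on compound 1, whose value is a limit and not a number: the limit of > 25 uM in this assay, at which 1 of the 3 values shown sits.

A single methyl at a single position cannot show whether the rise in the number follows from the size of the new group or from the place where it sits, and it gives no trend across groups. The compounds shown leave open how an ethyl, a methoxy or an amine on this same carbon would read in this assay, and whether a methyl on another carbon of the pyrazin-2-yl ring would give a step of similar size.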